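Thiophene in place of nitrophenyl on the amide carbonyl

This account rests on a few compounds, and the source may have more. Where it says the series, first, only, none or still open, it means among the compounds named here.

Of the compounds shown here, three have been measured in an assay on isolated protein for inhibition of aldehyde dehydrogenase 1A1 (Homo sapiens), read by spectrophotometry, tested at 10 uM; a lower number here means less inhibition, a higher number more inhibition at the concentration tested (going by the name of the read-out). Compound 1 `Cc1cccc(Cn2c(CN3CCN(C(=O)c4ccc([N+](=O)[O-])cc4)CC3)nc3ccccc32)c1` gives 24.3% in this assay, the lowest of the three numbers. Compound 3 `CC(C)CCn1c(CN2CCN(C(=O)c3ccco3)CC2)nc2ccccc21` gives 42.1%, which stands beyond the scatter above compound 1, and compound 2 `Cc1cccc(Cn2c(OC3CCN(C(=O)c4ccco4)CC3)nc3ccccc32)c1` gives 68.3%, furthest from compound 1. Compound 4 `Cc1cccc(Cn2c(CN3CCN(C(=O)c4cccs4)CC3)nc3ccccc32)c1` has not yet been measured. It differs from compound 1 in one place: thiophen-2-yl in place of 4-nitrophenyl on a carbonyl carbon. The 4-nitrophenyl, a six-membered aromatic ring of carbon only, leaves, and the smaller five-membered thiophen-2-yl enters on the carbonyl carbon. Because compound 3, carrying a five-membered heteroaryl carbonyl, gives 42.1%, the step is expected to be upward, with a number 17.7 percentage points higher from compound 1 to compound 4 (beyond the scatter) as the estimated change. Compound 4 is thus expected to reach about 42%, within 25% to 60%.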

Compound 4, a percentage reported as inhibition, at one concentration (the size of the read-out at that concentration, not a potency): 60.8%
Estimate against measurement, compound 4: 18.8 percentage points below; measured number above the stated range.
By their numbers in this assay, from the lowest: compound 1; then compound 3; then compounds 4 and 2 (each within the scatter of the next).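

On a carbonyl carbon whose other neighbours are an amide-type nitrogen in a ring, replacing 4-nitrophenyl with thiophen-2-yl raises the number in this assay by a large step (a number 36.5 percentage points higher from compound 1 to compound 4 (beyond the scatter)). Among the compounds shown here, this is the first reading of this position alone, and it shows that this one change moves the number beyond the scatter. Nothing at hand explains the rise.

Going by these compounds, whether a plain phenyl or a furan-2-yl on the same carbonyl carbon would give a similar number remains open. So does whether the step would hold with another group in place of the 3-methylbenzyl group of compound 4.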